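This account rests on a few compounds, and the source may have more. Where it says the series, first, only, none or still open, it means among the compounds named here.

In a functional assay on A549 cells (Homo sapiens) for antiproliferative activity, read by MTT assay, with a stated time of 72 h (on this read-out lower numbers stand for stronger inhibition and higher numbers for weaker inhibition), compound 1 (`Cc1nc(C)c(/C=C/C(=O)/C=C/c2cccc(O)c2)nc1C`) gives 4300 nM, compound 2 (`COc1ccc(/C=C/C(=O)/C=C/c2nc(C)c(C)nc2C)cc1`) gives 3500 nM and compound 3 (`COc1ccc(/C=C/C(=O)/C=C/c2nc(C)c(C)nc2C)c(OC)c1`) gives 3070 nM. Compound 2 therefore stands within the scatter of both other measured compounds, and these three values show no order among themselves.

Compound 4 (`Cc1nc(C)c(/C=C/C(=O)/C=C/c2ccc(Cl)cc2)nc1C`) is still unmeasured. It carries chloro in place of methoxy on an aromatic carbon, para to a large group: chloro in place of methoxy on an aromatic carbon.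

Within the data shown here, the one measured step that bears on this change is a 1.1-fold lower number from compound 2 to compound 3 (0.06 log units; within the scatter), for methoxy in place of hydrogen on an aromatic carbon. Among the measured compounds shown here, that step touches the same methoxy-bearing ring but does not exchange methoxy for chloro, and no chloro compound has a measured value yet. The evidence is therefore indirect, and no step beyond the scatter is expected in this assay, in either direction.

The expected step is a 1.1-fold lower number from compound 2 to compound 4 (0.05 log units; within the scatter). For compound 4 the estimated value is 3100 nM, with an expected range from 1500 nM to 6500 nM.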

Compound 4, half-maximal inhibitory concentration: 15800 nM
Beside the measured number, compound 4's estimate is 5.1-fold (0.71 log units) below it; measured number above the stated range.
By their numbers in this assay, from the lowest: compounds 3, 2 and 1 (each within the scatter of the next); then compound 4.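

In this assay the aromatic carbon para to a large group proves sensitive to the exchange of groups: chloro in place of methoxy gives a 4.5-fold higher number from compound 2 to compound 4 (0.65 log units; beyond the scatter) and is thus a step beyond the scatter, unlike the earlier methoxy in place of hydrogen. The change from 3-hydroxyphenyl to 4-chlorophenyl also gives a 3.7-fold higher number from compound 1 to compound 4 (0.57 log units; beyond the scatter) and likewise lies beyond the scatter, so compound 4 stands apart from compound 1 and compound 2, whose own values lie within the scatter of each other. No measured property on these compounds bears on this result.

As far as these compounds go, it remains open whether the step belongs to chloro itself or to the loss of methoxy. A fluoro group or an amine at the same position on the shared core would help separate these two readings.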